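The source may hold more compounds than are shown below. What is called first, only, known or untested is meant among the compounds shown, and "the series" means these compounds.

Measured compounds:
compound 1 `Cc1ccc(S(=O)(=O)NCc2ccc(CNC(=O)c3ccc(F)cn3)cc2)cc1`, an assay on MDA-MB-231 cells for binding affinity to C-X-C chemokine receptor type 4 (Homo sapiens), read by fluorescence and microscopy, with stated times of 10 min and 30 min; a lower number here means that less compound is needed, a higher number that more compound is needed for the effect: 1000 nM
compound 2 `O=C(NCc1ccc(CNS(=O)(=O)c2cccc(Cl)c2)cc1)c1ccc(F)cc1`, this assay: 1 nM

Compound 2 holds the lowest number of the two; compound 1 gives a far higher number, beyond the scatter, but it differs from compound 2 at more than one place and does not isolate any single change.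

Compound 3 `Cc1cccc(S(=O)(=O)NCc2ccc(CNC(=O)c3ccc(F)cc3)cc2)c1` differs from compound 2 by methyl in place of chloro on an aromatic carbon. For the measured compounds named here, no measured pair shows this change alone. In this assay a small step is expected, toward a higher number if any, within or only just beyond the scatter. Compound 3 is estimated at 3 nM, range 0.5 nM to 20 nM. The expected step is a 3.0-fold higher number from compound 2 to compound 3 (0.48 log units; beyond the scatter).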

Compound 3, effective concentration (reported as EC, without a stated level of effect): 1 nM
For compound 3 the middle estimate is 3.0-fold (0.48 log units) above the measured one; the range from low to high includes it.
By their numbers in this assay, from the lowest: compounds 2 and 3 (each within the scatter of the next); then compound 1.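

Methyl in place of chloro on an aromatic carbon gives the first single-place comparison in the series: in this assay the step reads no change at the digits printed from compound 2 to compound 3 (within the scatter). At this position, meta to a large group, 3-chlorophenyl and 3-methylphenyl cannot be told apart, so the low number of compound 2 does not depend on chloro itself.

Whether a methoxy group, an amine or a carboxylic acid at this place would keep that number remains open, as does which difference from compound 1 accounts for its far higher number. No available measurement explains why the two groups match.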